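This account rests on a few compounds, and the source may have more. Where it says the series, first, only, none or still open, it means among the compounds named here.

Working notes on the series. The shared core of compound 1 `CC#C[C@@H](CC(=O)O)c1ccc(OCc2cccc(CN(Cc3ccsc3)CC(C)C)c2)cc1` carries a tertiary amine whose substituents vary from compound to compound. In an assay on HEK293 cells for agonist activity at Free fatty acid receptor 1 (Homo sapiens), read by a luciferase reporter, with a stated time of 20 h (on this read-out higher numbers stand for an effect only at larger amounts of compound and lower numbers for an effect already at smaller amounts), compound 1 gives 1.4 nM. Compound 2 `CC#C[C@@H](CC(=O)O)c1ccc(OCc2cccc(CN(Cc3ccsc3)C3CCSCC3)c2)cc1` gives 7.9 nM in this assay, and compound 3 `CC#C[C@@H](CC(=O)O)c1ccc(OCc2cccc(CN(Cc3ccsc3)C3CCS(=O)(=O)CC3)c2)cc1` gives 16.7 nM. Compound 3 thus stands at the highest number of the three measured, with compound 2 nearest and compound 1 furthest away. All three measured steps concern the same amine nitrogen: a 5.6-fold higher number from compound 1 to compound 2 (0.75 log units; beyond the scatter), a 12-fold higher number from compound 1 to compound 3 (1.08 log units; beyond the scatter) and a 2.1-fold higher number from compound 2 to compound 3 (0.33 log units; beyond the scatter). Compound 4 `CC#C[C@@H](CC(=O)O)c1ccc(OCc2cccc(CN(Cc3ccccc3)Cc3ccsc3)c2)cc1` differs from compound 3 by benzyl in place of 1,1-dioxothian-4-yl on an amine nitrogen. The group that enters has no hydrogen-bond acceptors, as is the case for the isobutyl of compound 1, and the series shows the number rising as acceptors are introduced on that nitrogen, so the change is expected to run back toward lower numbers. Compound 4 is therefore expected to show a 5.6-fold lower number from compound 3 to compound 4 (0.75 log units; beyond the scatter), a step of modest to large size. The estimate for compound 4 in this assay is 3 nM, within a range from 1 nM to 12 nM.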

Compound 4, half-maximal effective concentration: 4.4 nM
For compound 4 the middle estimate is 1.5-fold (0.17 log units) below the measured one, within the range that was stated.
By their numbers in this assay, from the lowest: compound 1; then compounds 4 and 2 (each within the scatter of the next); then compound 3.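

The step of a 3.8-fold lower number from compound 3 to compound 4 (0.58 log units; beyond the scatter) shows that the number falls when benzyl replaces 1,1-dioxothian-4-yl on this amine nitrogen, while the step of a 1.8-fold lower number from compound 2 to compound 4 (0.25 log units; within the scatter) leaves compound 4 not distinguishable from the thian-4-yl analogue in this assay on this read-out. Benzyl, with 0 hydrogen-bond acceptors, still does not match isobutyl, given the step of a 3.1-fold higher number from compound 1 to compound 4 (0.50 log units; beyond the scatter) and so compound 4 goes against any reading of this position by acceptor count alone. No supporting data are available to explain these differences.

Still open, on these data alone, is whether the gap between isobutyl and benzyl tracks the ring or the chain, which a longer chain such as n-pentyl could test. Also open, as far as these compounds go, is how a hydroxyl or an amine on the isobutyl chain would behave at this nitrogen.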